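This account rests on a few compounds, and the source may have more. Where it says the series, first, only, none or still open, it means among the compounds named here.

In a functional assay on HT-29 cells (Homo sapiens) for antiproliferative activity, read by MTT assay, with a stated time of 48 h (a higher number here means a weaker inhibitor of growth, a lower number a stronger inhibitor of growth), the measured compounds are: compound 1 `Fc1ccc(C2=NN(C(=S)Nc3ccccc3)C(c3ccc4c(c3)OCCO4)C2)cc1` with 37600 nM; compound 2 `O=[N+]([O-])c1ccc(C2=NN(C(=S)Nc3ccccc3)C(c3ccc4c(c3)OCCO4)C2)cc1` with 153000 nM; and compound 3 `S=C(Nc1ccccc1)N1N=C(c2cccc(Cl)c2)CC1c1ccc2c(c1)OCCO2`, which reached no number. Compound 3 sits at the limit of > 200000 nM in this assay, at which 1 of the 3 values shown sits, so its value > 200000 nM is a limit of the assay and not a number. Compound 3 thus stands at the weak end of the three; the steps onto it were an at least 5.3-fold higher number from compound 1 to compound 3 (0.72 log units; beyond the scatter) and an at least 1.3-fold higher number from compound 2 to compound 3 (0.11 log units; that floor lies within the scatter).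

Compound 4 `Cc1ccc(C2=NN(C(=S)Nc3ccccc3)C(c3ccc4c(c3)OCCO4)C2)cc1C` differs from compound 3 by 3,4-dimethylphenyl in place of 3-chlorophenyl on a carbon with a double bond to nitrogen. Going by the values given here, both earlier exchanges of the aryl group on that carbon raised the number toward the limit, and no measured pair mirrors this dimethyl change, so any expectation is broad. Compound 4 is expected to give 100000 nM, between 30000 nM and 300000 nM. That estimate means an expected at least 2.0-fold lower number from compound 3 to compound 4 (0.30 log units; that floor lies within the scatter), with a real chance that only a limit is again reported.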

Compound 4, concentration for 50% growth inhibition: 133000 nM
The estimate for compound 4 lay 1.3-fold (0.12 log units) below the measured number, within the range that was stated.
By their numbers in this assay, from the lowest: compound 1; then compounds 4 and 2 (each within the scatter of the next). At a limit, above all of these: compound 3.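

In this assay, 3,4-dimethylphenyl on the carbon with a double bond to nitrogen cannot be told apart from 4-nitrophenyl, with a 1.2-fold lower number from compound 2 to compound 4 (0.06 log units; within the scatter), while it stays short of 4-fluorophenyl, with a 3.5-fold higher number from compound 1 to compound 4 (0.55 log units; beyond the scatter). Against 3-chlorophenyl there is only a floor, an at least 1.5-fold lower number from compound 3 to compound 4 (0.17 log units; that floor lies within the scatter), so that change cannot be sized. Compound 3 remains a limit of the assay and not a number: the limit of > 200000 nM in this assay, at which 1 of the 4 values shown sits.

The compounds shown leave open whether an amine or a carboxylic acid on this aryl group would bring the number under that of compound 1. Going by these compounds, whether a single methyl would do the same also stays open.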